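Working notes: the step from compound 3 to compound 4

A few compounds are considered here, and "the series" means these few. Any claim that something is new, unique, unknown or untested is made for them only; others in the source may bear on it.

Values so far in a functional assay on HEK293 cells (Homo sapiens) for cytotoxicity; on this read-out lower numbers stand for higher toxicity in this test and higher numbers for lower toxicity in this test (each one a limit, not a number)
compound 1 `COc1ccc([C@H]2CC(=O)N(c3cccc(NCc4ccoc4)c3)C2)cc1OC1CCCC1` gives > 10000 nM (a limit)
compound 2 `COc1ccc([C@H]2CC(=O)N(c3cccc(NS(=O)(=O)c4ccc(F)cc4)c3)C2)cc1OC1CCCC1` gives > 10000 nM (a limit)
compound 3 `COc1ccc([C@H]2CC(=O)N(c3cccc(NS(=O)(=O)c4ccccc4C)c3)C2)cc1OC1CCCC1` gives > 10000 nM (a limit)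

Compound 3 stands at > 10000 nM as a limit and not a number. Among the measured compounds shown here, it shares its place with the other two compounds, and the series so far reads the limit of > 10000 nM in this assay, at which 3 of the 3 values shown sit, with no measured number to work from.

The next change is 3-bromo-5-chloro-1-methyl-1H-pyrazol-4-yl in place of 2-methylphenyl on a sulfonyl sulfur, which gives compound 4 `COc1ccc([C@H]2CC(=O)N(c3cccc(NS(=O)(=O)c4c(Br)nn(C)c4Cl)c3)C2)cc1OC1CCCC1` and is counted as 3-bromo-5-chloro-1-methyl-1H-pyrazol-4-yl in place of 2-methylphenyl on a sulfonyl sulfur (with the sulfonamide nitrogen as the other neighbour named for that sulfur).

The closest measured change sits at the same sulfonyl sulfur and reads a step that the two limits leave unreadable from compound 2 to compound 3 without offering a size. The two changes on the nitrogen read a step that the two limits leave unreadable from compound 1 to compound 2 and a step that the two limits leave unreadable from compound 1 to compound 3 and offer none either.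

In this assay no step beyond the scatter is expected, and no direction can be assigned, so the expected step is a step that the limit leaves unreadable from compound 3 to compound 4 as estimated here. For compound 4 the estimate is 15000 nM with an expected range from 6000 nM to 30000 nM and a report as a limit is the likeliest outcome.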

Compound 4, half-maximal cytotoxic concentration: > 10000 nM
Compound 4 was reported as a limit; the forecaster's own chance of this, stated with the estimate: 80%; the middle value lies beyond the limit too.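

The steps from compound 1, compound 2 and compound 3 to compound 4 in this assay cannot be read, because every value is a limit and not a number: the limit of > 10000 nM in this assay, at which 4 of the 4 values shown sit.

The compounds shown leave open how far any of the four lies from that limit, and whether any change on the sulfonyl sulfur or the nitrogen alters toxicity in this test.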